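The compounds below may be only part of what the source reports. "The series", "measured", "known", "first", "only" and "open" are said of these compounds alone.

Measured compounds:
- compound 1, `Cc1cn([C@@H]2O[C@@H]3COC(=O)[C@]3(OS(C)(=O)=O)[C@H]2O)c(=O)[nH]c1=O`, gives 160000 nM in a functional assay on CCRF-CEM cells (Homo sapiens); a higher number here means that more compound is tolerated, a lower number that less compound is tolerated
- compound 2, `C=C(C)C(=O)NC(=O)NC1=CS(=O)(=O)O[C@@]12[C@@H](CO[Si](C)(C)C(C)(C)C)O[C@@H](n1cc(C)c(=O)n(C)c1=O)[C@@H]2O[Si](C)(C)C(C)(C)C`, gives 1200 nM in this assay
- compound 3, `Cc1cn([C@@H]2O[C@@H]3COC4(O)CS(=O)(=O)O[C@@]34[C@H]2O[Si](C)(C)C(C)(C)C)c(=O)[nH]c1=O`, gives 100000 nM in this assay

Among these three, compound 2 stands at the lowest number: the gap from compound 2 to compound 3 and the gap from compound 2 to compound 1 both lie beyond the usual scatter, so compound 2 is the one of which the least is tolerated by the cells. Among the compounds with values here, no pair of these measured compounds differs in only one place, so no single step between them can be read off, and nothing is known here about how a change of one group shifts the number.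

Compound 4, `Cc1cn([C@@H]2O[C@H](CO[Si](C)(C)C(C)(C)C)[C@@]3(OS(=O)(=O)C=C3NC(=O)NC(=O)c3ccccc3)[C@H]2O[Si](C)(C)C(C)(C)C)c(=O)n(C)c1=O`, has not been measured. It differs from compound 2 in one place: phenyl in place of 1-methylethenyl on a carbonyl carbon. Both groups carry no hydrogen-bond donors or acceptors, and the rest of the molecule is unchanged. Within the data shown here, with no measured step to lean on, the expectation is a small shift, within or near the scatter, and a modest rise is estimated as a 1.7-fold higher number from compound 2 to compound 4 (0.22 log units; within the scatter). For compound 4 the expected value in this assay is 2000 nM, with a range from 600 nM to 7000 nM.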

Compound 4, half-maximal cytotoxic concentration: 2290 nM
Compound 4: the middle estimate sits 1.1-fold (0.06 log units) below what was measured, within the range that was stated.
By their numbers in this assay, from the lowest: compounds 2 and 4 (each within the scatter of the next); then compounds 3 and 1 (each within the scatter of the next).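

In this assay, within the data shown here, phenyl in place of 1-methylethenyl on a carbonyl carbon gives a 1.9-fold higher number from compound 2 to compound 4 (0.28 log units; within the scatter) and this is the first step in the set that changes one place only. At this position, on a carbonyl carbon whose other neighbour is an amide-type nitrogen, the benzoyl and (1-methylethenyl)carbonyl forms therefore cannot be told apart in this measurement, even though the change swaps an open group with a double bond for a six-membered aromatic ring. Nothing available here explains this result.

Still open, from the compounds shown here alone, is whether an amine, a carboxylic acid or a longer saturated chain on this carbonyl carbon would move the number beyond the scatter. The two compounds also leave open how a substituted phenyl, such as one carrying a fluorine or a methoxy group, would read at this position.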